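Geranyl ether exchanged for a carbamate on the shared core

The compounds below may be only part of what the source reports. "The series", "measured", "known", "first", "only" and "open" are said of these compounds alone.

Working notes on a small set of analogues on one core, all tested in a functional assay on PANC-1 cells (Homo sapiens) for inhibition, read by MTT assay, with a stated time of 24 h, tested at 10 uM; on this read-out lower numbers stand for less inhibition and higher numbers for more inhibition at the one concentration tested (going by the name of the read-out). Compound 1 `CC(C)=CCC/C(C)=C/COc1cc(=O)n(CCCO)c2c1CC(CC=C(C)C)C(C)(C)C2` gives 10.6% in this assay. Compound 2 `CC(C)=CCC1Cc2c(OCCCNS(=O)(=O)c3ccc(C(F)(F)F)cc3)cc(=O)n(CCCO)c2CC1(C)C` gives 29.6% in this assay. On these two numbers compound 1 stands lowest, and the gap to compound 2 lies beyond the scatter.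

Compound 3 `CC(C)=CCC1Cc2c(OC(=O)Nc3ccc(F)cc3F)cc(=O)n(CCCO)c2CC1(C)C` has not yet been measured in this assay. Relative to compound 1 the change is (2,4-difluorophenyl)carbamoyl in place of 3,7-dimethylocta-2,6-dien-1-yl on an oxygen on an aromatic ring. Within the data shown here, no step between measured compounds matches this exchange, so only the two values shown can guide an expectation. Among the measured analogues, only compound 2 carries an aromatic ring in its side chain in place of the chain of compound 1. In this assay compound 2 gives 29.6%, which is the only hint available.

For compound 3 the expected step from compound 1 is a number 14.4 percentage points higher from compound 1 to compound 3 (beyond the scatter) in this assay, upward and probably beyond the scatter. The estimate for compound 3 in this assay is 25%, with a range from 5% to 50%.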

Compound 3, a percentage reported as inhibition, at one concentration (the size of the read-out at that concentration, not a potency): 69.7%
Compound 3: the middle estimate sits 44.7 percentage points below what was measured; measured number above the stated range.
By their numbers in this assay, from the lowest: compound 1; then compound 2; then compound 3.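

In this assay, placing (2,4-difluorophenyl)carbamoyl instead of 3,7-dimethylocta-2,6-dien-1-yl on the oxygen on an aromatic ring gives a number 59.1 percentage points higher from compound 1 to compound 3 (beyond the scatter), so this single position can carry a far wider span of the read-out than the first two compounds revealed. Compound 2, which also has an aromatic ring in its side chain, gives 29.6% and compound 3 gives 69.7%, so the presence of an aromatic ring alone does not set the number; the two side chains differ in both their link to the oxygen and the substituents on the ring. Nothing measured here accounts for the size of this step.

The compounds shown leave open which part of the entering group goes with the higher number, the carbamoyl link or the two fluorines on the ring. An unsubstituted phenylcarbamoyl would speak to the fluorines, while a 2,4-difluorobenzoyl group, or a 2,4-difluorobenzyl group, on the same oxygen would speak to the link and the amide hydrogen.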